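The source may hold more compounds than are shown below. What is called first, only, known or untested is meant among the compounds shown, and "the series" means these compounds.

Compound 1 `N#Cc1nc2c(-c3nc4ccccc4[nH]3)c(N)n(CCO)c2nc1C#N`: in a functional assay on K562 cells (Homo sapiens) for antiproliferative activity, read by MTT assay, with a stated time of 48 h (a higher number here means a weaker inhibitor, a lower number a stronger inhibitor), compound 1 reaches only the limit > 50000 nM.
Compound 2 `CN(C)CCCn1c(N)c(-c2nc3ccccc3[nH]2)c2nc(C#N)c(C#N)nc21`: in this assay compound 2 gives 1730 nM.
Compound 3 `CCCCn1c(N)c(-c2nc3ccccc3[nH]2)c2nc(C#N)c(C#N)nc21`: in this assay compound 3 reaches only the limit > 50000 nM.

Compound 3 thus stands at the limit of this assay, where two of the three measured compounds sit, as the limit of > 50000 nM in this assay, at which 2 of the 3 values shown sit, records. The unmeasured compound 4 `CCN(CC)CCCCn1c(N)c(-c2nc3ccccc3[nH]2)c2nc(C#N)c(C#N)nc21` differs from compound 3 by diethylamino in place of hydrogen on a saturated chain carbon, four bonds along the chain from an aromatic nitrogen. The step that bears on this is an at least 28-fold higher number from compound 2 to compound 3 (1.46 log units; beyond the scatter), where methyl took the place of dimethylamino; its counterpart, an at least 28-fold lower number from compound 1 to compound 2 (1.46 log units; beyond the scatter), ran the other way. Both were large and beyond the scatter, so adding diethylamino is expected to give an at least 25-fold lower number from compound 3 to compound 4 (1.39 log units; beyond the scatter). Compound 4 is therefore estimated at 2000 nM, within 500 nM to 10000 nM.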

Compound 4, half-maximal inhibitory concentration: 1440 nM
The estimate for compound 4 lay 1.4-fold (0.14 log units) above the measured number, within the range that was stated.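

In this assay, diethylamino on a saturated chain carbon, four bonds along the chain from an aromatic nitrogen, gives an at least 34-fold lower number from compound 3 to compound 4 (1.54 log units; beyond the scatter), so the gain seen with dimethylamino in compound 2 is not tied to that one amine or chain. Against compound 2 there is a 1.2-fold lower number from compound 2 to compound 4 (0.08 log units; within the scatter), which leaves the two amine chains indistinguishable here. The step of an at least 34-fold lower number from compound 1 to compound 4 (1.54 log units; beyond the scatter) likewise starts from a limit, not a number: the limit of > 50000 nM in this assay, at which 2 of the 4 values shown sit.

Open, from the compounds shown here alone, is whether a piperidine or morpholine on this chain would match diethylamino. Also open, going by these compounds, is whether a longer chain carrying diethylamino would hold this level.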